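Replacing furan-2-yl with pyridin-3-yl on the shared core

The compounds below may be only part of what the source reports. "The series", "measured", "known", "first", "only" and "open" are said of these compounds alone.

Measured so far in a functional assay on MDA-MB-231 cells (Homo sapiens) for cytotoxicity, read by ELISA, with a stated time of 2 days (on this read-out lower numbers stand for stronger inhibition and higher numbers for weaker inhibition), are these compounds:
- compound 1 `Oc1cccc(-c2cc(-c3ccccc3)nc(-c3ccccc3)c2)c1` gives 19500 nM here
- compound 2 `Oc1cccc(-c2cc(-c3ccccc3)nc(-c3cccs3)c2)c1` gives 17700 nM here
- compound 3 `Oc1cccc(-c2cc(-c3ccccc3)nc(-c3ccco3)c2)c1` gives 20800 nM here

Compound 3 has no separate place among these values. The measurements show a 1.1-fold higher number from compound 1 to compound 3 (0.03 log units; within the scatter) and a 1.2-fold higher number from compound 2 to compound 3 (0.07 log units; within the scatter) as its links to the other two. The next structure is compound 4 `Oc1cccc(-c2cc(-c3ccccc3)nc(-c3cccnc3)c2)c1` and its difference from compound 3 is pyridin-3-yl in place of furan-2-yl on an aromatic carbon with pyridin-3-yl in place of furan-2-yl on an aromatic carbon. The swaps already measured on that carbon bear on this change. Besides the two steps above there is a 1.1-fold lower number from compound 1 to compound 2 (0.04 log units; within the scatter) as the third, so none of the three separates the compounds. Pyridin-3-yl itself has not been measured on this core, so the evidence is indirect. The expected change is a 1.1-fold lower number from compound 3 to compound 4 (0.04 log units; within the scatter) and so none beyond the scatter. In this assay compound 4 is estimated at 19000 nM with an expected range of 9000 nM to 38000 nM overall.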

Compound 4, half-maximal inhibitory concentration: 22800 nM
Beside the measured number, compound 4's estimate is 1.2-fold (0.08 log units) below it, and the stated range covers the measured number.
By their numbers in this assay, from the lowest: compounds 2, 1, 3 and 4 (each within the scatter of the next).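

In this assay pyridin-3-yl on this carbon leaves the number where the other three groups put it, with a 1.1-fold higher number from compound 3 to compound 4 (0.04 log units; within the scatter) and a 1.3-fold higher number from compound 2 to compound 4 (0.11 log units; within the scatter) and a 1.2-fold higher number from compound 1 to compound 4 (0.07 log units; within the scatter). The earlier compounds shown here carried phenyl and two five-membered aromatic rings with one hetero atom, and compound 4 adds a six-membered aromatic ring with one hetero atom, yet neither ring size nor the hetero atom separates the four compounds at this carbon. Nothing available accounts for this flat result.

The compounds shown leave open whether an amine or a carboxylic acid on this carbon would move the number beyond the scatter. Going by these compounds, they also all keep the 3-hydroxyphenyl group and the phenyl group, so the effect of a change at those places remains open.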